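This account rests on a few compounds, and the source may have more. Where it says the series, first, only, none or still open, it means among the compounds named here.

Of the compounds shown here, three with a shared core have been measured in an assay on CHO cells for displacement of a labelled ligand from prostaglandin D2 receptor 2 (Homo sapiens), read by scintillation counting; on this read-out lower numbers stand for stronger inhibition and higher numbers for weaker inhibition. Compound 1 `Cc1ccc(S(=O)(=O)NC(C)C)cc1C#Cc1cc(Cl)ccc1OCC(=O)O` gives 3.4 nM, the lowest of the three numbers. Compound 3 `CCCS(=O)(=O)c1ccc(C)c(C#Cc2cc(C#N)ccc2OCC(=O)O)c1` stands nearest to it with 7 nM, a gap that lies beyond the usual scatter. Compound 2 `O=C(O)COc1ccc(Cl)cc1C#Cc1ccc(Cl)s1`, which carries a different ring on the far side of the alkyne, gives 183 nM and is the furthest from compound 1, also well beyond the scatter.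

The unmeasured compound 4 `Cc1ccc(S(=O)(=O)NC(C)(C)C)cc1C#Cc1cc(Cl)ccc1OCC(=O)O` differs from compound 1 in a single place: methyl in place of hydrogen on a saturated chain carbon bound to two saturated chain carbons and a sulfonamide nitrogen. Going by the values given here, no pair of measured compounds shows this kind of change, so its effect must be guessed from the closeness of the two structures alone. Adding one carbon on the chain attached to the sulfonamide nitrogen is expected to leave the number roughly where it is, and the step from compound 1 to compound 4 is expected to be a 1.2-fold higher number from compound 1 to compound 4 (0.07 log units; within the scatter), within the scatter. For compound 4 the estimate in this assay is 4 nM, with a range from 1.5 nM to 12 nM.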

Compound 4, inhibition constant: 5 nM
Compound 4: the middle estimate sits 1.3-fold (0.10 log units) below what was measured, and the stated range covers the measured number.
By their numbers in this assay, from the lowest: compounds 1, 4 and 3 (each within the scatter of the next, the first and the last beyond it); then compound 2.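

Changing isopropyl to tert-butyl on the sulfonamide gives a 1.5-fold higher number from compound 1 to compound 4 (0.17 log units; within the scatter) in this assay. Going by these compounds alone, this is the first direct look at this position, and the added methyl, on a saturated chain carbon bound to two saturated chain carbons and a sulfonamide nitrogen, leaves compound 1 and compound 4 indistinguishable on this read-out. Nothing available explains why the added methyl makes so little difference.

Going by these compounds, a single pair cannot show how far this tolerance extends, so it remains open whether a longer chain, a ring such as cyclohexyl, or a chain ending in an amine or a carboxylic acid would keep the number in the same range. On these data alone, it is also open whether the same methyl would have a similarly small effect on a different shared-core compound.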